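This account rests on a few compounds, and the source may have more. Where it says the series, first, only, none or still open, it means among the compounds named here.

In a functional assay on SW-620 cells (Homo sapiens) for cytotoxicity, read by MTT assay, with a stated time of 48 h (on this read-out higher numbers stand for weaker inhibition and lower numbers for stronger inhibition), compound 1 `CCCCCCCCCCCCNC(=O)[C@@H](NC(=O)c1ccccc1)[C@@H](C)O` gives 200000 nM, compound 2 `CCCCCCCCCCCCCCNC(=O)[C@@H](NC(=O)c1ccccc1)[C@@H](C)O` gives 200000 nM, and compound 3 `CCCCCCCCCCCCCCCCCCNC(=O)[C@@H](NC(=O)c1ccccc1)[C@@H](C)O` gives 200000 nM. The three share one core and differ only in the length of the saturated chain on the amide-type nitrogen. Lengthening that chain moved nothing: no change at the digits printed from compound 1 to compound 2 (within the scatter), no change at the digits printed from compound 1 to compound 3 (within the scatter) and no change at the digits printed from compound 2 to compound 3 (within the scatter). Compound 3 therefore sits level with compounds 1 and 2 in this assay.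

Compound 4 `CCCCCCCCCCCCCCCCCCNC(=O)[C@@H](NC(=O)/C=C/c1ccccc1)[C@@H](C)O` is made from compound 3 by a change at a different place: 2-phenylethenyl in place of phenyl on a carbonyl carbon. Among the compounds with values here, no measured pair alters this part of the core; every step recorded so far concerns the chain only, and all of those were flat. Within the data shown here, there is thus no recorded step that bears directly on this change. Without any such step, the expectation for compound 4 is a value at the same level, no change at the digits printed from compound 3 to compound 4 (within the scatter), in this assay. Compound 4 is therefore estimated at 200000 nM, with a range from 80000 nM to 300000 nM.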

Compound 4, half-maximal inhibitory concentration: 200000 nM
Compound 4: the middle estimate sits on the measured number at the digits printed, and the stated range covers the measured number.
By their numbers in this assay, from the lowest: compounds 1, 2, 3 and 4 (each within the scatter of the next).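

Within the data shown here, until now every recorded step concerned the saturated chain, and this is the first to alter a different place, the group on a carbonyl carbon. In this assay, among these compounds, putting 2-phenylethenyl in place of phenyl, which brings in a double bond outside the aromatic ring, gives no change at the digits printed from compound 3 to compound 4 (within the scatter), so this second place, like the chain, shows no response to the one change tried here. No measurement at hand offers an explanation for this flat result.

With all four compounds level, the set does not show whether any group at either place can move the number in this assay. Going by these compounds, it remains open whether an amine or a carboxylic acid on the phenyl ring, or a much shorter chain such as hexyl on the amide-type nitrogen, would give a different value.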